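Working notes on a purinoceptor antagonist amide series

The source may report more compounds than this note shows. Statements on the series, on what has been measured and on what is new or still open speak of the compounds shown alone.

Two compounds have been run in an assay on HEK293 cells for antagonist activity at P2X purinoceptor 7 (Homo sapiens), read by fluorescence, with a stated time of 2 h; a lower number here means a stronger inhibitor, a higher number a weaker inhibitor. Compound 1 `CS(=O)(=O)Oc1ccc(-c2cncn2C2CCN(C(=O)c3ccc(Cl)c(C(F)(F)F)c3)CC2)cc1` gives 1570 nM. Compound 2 `COc1ccc(C(=O)N2CCC(n3cncc3-c3ccc(OS(=O)(=O)c4cccc5cnccc45)cc3)CC2)cc1OC` gives 259 nM, the lower of the two numbers, and the gap between compound 2 and compound 1 lies beyond the usual scatter, so compound 2 is the stronger inhibitor of the pair. Compound 3 `CN(C)c1cccc(C(=O)N2CCC(n3cncc3-c3ccc(OS(=O)(=O)c4cccc5cnccc45)cc3)CC2)c1` has not yet been measured. It differs from compound 2 in one place: 3-(dimethylamino)phenyl in place of 3,4-dimethoxyphenyl on a carbonyl carbon. Going by the values given here, no measured pair of compounds shows this change, so its effect cannot be read from the numbers at hand, and compound 1 differs from compound 2 in other places too. The expected step is therefore a modest one, a 1.5-fold higher number from compound 2 to compound 3 (0.19 log units; within the scatter), no more than a slight weakening and possibly within the scatter. The estimate for compound 3 in this assay is 400 nM, with a range from 150 nM to 1200 nM.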

Compound 3, half-maximal inhibitory concentration: 155 nM
Compound 3: the middle estimate sits 2.6-fold (0.41 log units) above what was measured; low and high end bracket the measured number.
By their numbers in this assay, from the lowest: compounds 3 and 2 (each within the scatter of the next); then compound 1.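

In this assay the change from 3,4-dimethoxyphenyl to 3-(dimethylamino)phenyl on the carbonyl carbon gives a 1.7-fold lower number from compound 2 to compound 3 (0.22 log units; within the scatter) and so leaves the two compounds inseparable. Going by these compounds alone, this is the first comparison that differs in one place only, and it shows that this position can carry a dimethylamino group in place of two methoxy groups, with one hydrogen-bond acceptor instead of two, without a step beyond the scatter. The data on hand offer no explanation for this outcome.

From the compounds shown here alone, whether an unsubstituted phenyl, a single methoxy group, a primary amine or a carboxylic acid at this position would stay close to these two compounds remains open. Within the data shown here, compound 1 differs from compound 2 and compound 3 in more than one place, so no step to it can be read.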